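Replacing the aromatic alkyne cap with a saturated ring

The source may report more compounds than this note shows. Statements on the series, on what has been measured and on what is new or still open speak of the compounds shown alone.

Three compounds built on one shared core differ only in the group attached to a triple-bonded carbon. Compound 1 `CNC(=O)[C@@]12C[C@@H]1[C@@H](n1cnc3c(NC)nc(C#Cc4cccc(C(F)(F)F)c4)nc31)[C@H](O)[C@@H]2O` gives 3.39 nM in an assay on CHO cells for displacement of a labelled ligand from adenosine receptor A3 (Homo sapiens), read by scintillation counting, with a stated time of 60 min; on this read-out lower numbers stand for stronger inhibition and higher numbers for weaker inhibition. Compound 2 `CNC(=O)[C@@]12C[C@@H]1[C@@H](n1cnc3c(NC)nc(C#Cc4cccnn4)nc31)[C@H](O)[C@@H]2O` gives 3.53 nM in this assay. Compound 3 `CCc1ccc(C#Cc2nc(NC)c3ncn([C@H]4[C@H](O)[C@H](O)[C@]5(C(=O)NC)C[C@H]45)c3n2)o1` gives 1.5 nM in this assay and has the lowest number of the three: the steps of a 2.3-fold lower number from compound 1 to compound 3 (0.35 log units; beyond the scatter) and a 2.4-fold lower number from compound 2 to compound 3 (0.37 log units; beyond the scatter) both lie beyond the scatter, whereas the step of a 1.0-fold higher number from compound 1 to compound 2 (0.02 log units; within the scatter) stays within it. Compound 4 `CNC(=O)[C@@]12C[C@@H]1[C@@H](n1cnc3c(NC)nc(C#CC4CCCCC4)nc31)[C@H](O)[C@@H]2O` carries the change (cyclohexyl in place of 5-ethylfuran-2-yl on a triple-bonded carbon). Each measured step exchanged one aromatic group for another, and none moved the number by more than a modest amount. Among the compounds with values here, no measured step involves a non-aromatic ring or the loss of the single acceptor counted in the leaving group, so the direction of this change is not anchored by any measured pair. A modest rise in the number is therefore expected for compound 4, as the step of a 3.3-fold higher number from compound 3 to compound 4 (0.52 log units; beyond the scatter). Compound 4 is estimated at 5 nM in this assay, with a range from 1.2 nM to 20 nM.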

Compound 4, inhibition constant: 1.68 nM
For compound 4 the middle estimate is 3.0-fold (0.47 log units) above the measured one; measured number inside the range.
By their numbers in this assay, from the lowest: compounds 3, 4, 1 and 2 (each within the scatter of the next, the first and the last beyond it).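

In this assay the step of a 1.1-fold higher number from compound 3 to compound 4 (0.05 log units; within the scatter) shows that this place, on a triple-bonded carbon, accepts a six-membered non-aromatic ring of carbon only, and that losing the hydrogen-bond acceptor of 5-ethylfuran-2-yl leaves the number within the scatter. Against the other two groups, the steps are a 2.1-fold lower number from compound 2 to compound 4 (0.32 log units; beyond the scatter) and a 2.0-fold lower number from compound 1 to compound 4 (0.30 log units; within the scatter), so an aromatic ring at this place is not required for a low number in these compounds, and only the step from pyridazin-3-yl lies beyond the scatter. Nothing available speaks to what lies behind these numbers.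

From the compounds shown here alone, whether a smaller ring such as cyclopropyl, an open chain such as n-butyl, or a ring holding an amine such as piperidin-4-yl would hold the number at this place stays open. Going by these compounds, how compound 4 behaves at other adenosine receptors also stays open.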